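A few compounds are considered here, and "the series" means these few. Any claim that something is new, unique, unknown or untested is made for them only; others in the source may bear on it.

Measured compounds:
compound 1 `Oc1ccc(Nc2cncc(N3CC4CC(C3)N4)c2)cc1` gives 0.342 nM in an assay on cell membranes for displacement of a labelled ligand from Neuronal acetylcholine receptor; alpha4/beta2 (Rattus norvegicus); a higher number here means a weaker inhibitor, a lower number a stronger inhibitor
compound 2 `Fc1ccc(Nc2cncc(N3CC4CC(C3)N4)c2)cc1` gives 0.091 nM in this assay

Compound 2 holds the lower of the two numbers, with compound 1 the nearest, separated by a 3.8-fold lower number from compound 1 to compound 2 (0.57 log units; beyond the scatter). Compound 3 `c1ccc(Nc2cncc(N3CC4CC(C3)N4)c2)cc1` differs from compound 2 by hydrogen in place of fluoro on an aromatic carbon, at a position para to a large group. Among the compounds with values here, the only measured step that bears on it is a 3.8-fold lower number from compound 1 to compound 2 (0.57 log units; beyond the scatter), which shows a modest change at this position. A step of similar or smaller size, toward a higher number, is expected from compound 2 to compound 3, namely a 2.2-fold higher number from compound 2 to compound 3 (0.34 log units; beyond the scatter). Compound 3 is therefore expected to give about 0.2 nM, within 0.07 nM to 0.6 nM.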

Compound 3, inhibition constant: 0.0807 nM
For compound 3 the middle estimate is 2.5-fold (0.39 log units) above the measured one, within the range that was stated.
By their numbers in this assay, from the lowest: compounds 3 and 2 (each within the scatter of the next); then compound 1.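

In this assay, hydrogen and fluoro at this position cannot be told apart, with a 1.1-fold lower number from compound 2 to compound 3 (0.05 log units; within the scatter), so the fluoro is not needed for the low number seen with compound 2. The earlier step from hydroxy to fluoro therefore reads differently: a 4.2-fold lower number from compound 1 to compound 3 (0.63 log units; beyond the scatter) shows that hydroxy alone stands apart from the other two groups here, as does a 3.8-fold lower number from compound 1 to compound 2 (0.57 log units; beyond the scatter). Nothing available explains this difference.

On these data alone, whether a methoxy group or an amine at this position would fall with hydroxy, or with fluoro and hydrogen, remains open.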